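Phenyl for trifluoromethyl: one step from compound 2

This account rests on a few compounds, and the source may have more. Where it says the series, first, only, none or still open, it means among the compounds named here.

In an assay on isolated protein for inhibition of protein kinase C delta type (Homo sapiens), read by TR-FRET, with a stated time of 2 h (on this read-out lower numbers stand for stronger inhibition and higher numbers for weaker inhibition), compound 2 `N#Cc1cnc(NCc2cncnc2C(F)(F)F)cc1N[C@H]1CC[C@@H](O)CC1` gives 450 nM, the only number shown in this set. Compound 1 `N#Cc1cnc(NCc2cnccc2C(F)(F)F)cc1NCCC1CCOCC1` reaches a limit of the assay, > 10000 nM, rather than a number. Going by the values given here, because of the limit of > 10000 nM in this assay, at which 1 of the 2 values shown sits, no step between measured compounds can be sized here. Compound 3 `N#Cc1cnc(NCc2cncnc2-c2ccccc2)cc1N[C@H]1CC[C@@H](O)CC1` differs from compound 2 by phenyl in place of trifluoromethyl on an aromatic carbon. Among the compounds with values here, with no measured step to lean on, the expected shift from compound 2 to compound 3 is a 1.3-fold higher number from compound 2 to compound 3 (0.12 log units; within the scatter), and it may well sit within the scatter. For compound 3 the estimate in this assay is 600 nM, with a range from 150 nM to 3000 nM.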

Compound 3, half-maximal inhibitory concentration: 90 nM
For compound 3 the middle estimate is 6.7-fold (0.82 log units) above the measured one; measured number outside the range, below it.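

In this assay, going by these compounds alone, phenyl in place of trifluoromethyl on an aromatic carbon gives a 5.0-fold lower number from compound 2 to compound 3 (0.70 log units; beyond the scatter) and is the first step that can be sized. This position, on a six-membered aromatic ring with 2 nitrogen, therefore takes a whole aromatic ring of carbon only, and the number falls rather than rises.

From the compounds shown here alone, whether an amine, a methoxy group or a longer chain at this position would keep that gain stays open. Compound 1 sits at a limit of the assay, and no step to it can be read: the limit of > 10000 nM in this assay, at which 1 of the 3 values shown sits.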